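Adding a methyl to the pyrrolidine of compound 3

The compounds below may be only part of what the source reports. "The series", "measured", "known", "first", "only" and "open" are said of these compounds alone.

Measured compounds:
compound 1 `CC1=C(c2cccc(O)c2)[C@H](c2ccc(OC[C@H](C)N3CC[C@@H](C)C3)cc2)Oc2ccc(O)cc21` gives 0.1 nM in a functional assay on MCF7 cells (Homo sapiens) for antiproliferative activity, read by CellTiter-Glo, with a stated time of 5 days; on this read-out higher numbers stand for weaker inhibition and lower numbers for stronger inhibition
compound 2 `CC1=C(c2cccc(O)c2)C(c2ccc(OC[C@@H](C)N3CC[C@H](C)C3)cc2)Oc2ccc(O)cc21` gives 0.2 nM in this assay
compound 3 `CC1=C(c2cccc(O)c2)C(c2ccc(OC[C@H](C)N3CCCC3)cc2)Oc2ccc(O)cc21` gives 0.2 nM in this assay

Compound 3 stands level with compound 2 at the digits shown, and the two together hold the highest numbers of the three; compound 1 is the furthest from compound 3, at a number lower by an amount that still sits within the scatter. Compound 4 `CC1=C(c2cccc(O)c2)C(c2ccc(OC[C@H](C)N3CC[C@H](C)C3)cc2)Oc2ccc(O)cc21` differs from compound 3 by methyl in place of hydrogen on a saturated ring carbon, which read one bond further out is pyrrolidin-1-yl to 3-methylpyrrolidin-1-yl.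

Among the measured compounds shown here, two measured steps bear on this change. The step of no change at the digits printed from compound 2 to compound 3 (within the scatter) removed a methyl from the same ring, together with the configurations noted in the fact that one of compounds 1 and 2 is drawn with a defined configuration and the other without, at the place where they differ, and moved nothing beyond the scatter. The step of a 2.0-fold higher number from compound 1 to compound 2 (0.30 log units; within the scatter) changed only drawn configurations and stayed within the scatter as well. The data therefore give no reason to expect a move in this assay beyond the scatter in either direction. Compound 4 is expected to give about 0.2 nM, between 0.07 nM and 0.5 nM, which is estimated as no change at the digits printed from compound 3 to compound 4 (within the scatter).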

Compound 4, half-maximal inhibitory concentration: 0.2 nM
Compound 4: middle estimate and measured number agree at the digits printed; the measured number falls inside the stated range.
By their numbers in this assay, from the lowest: compounds 1, 2, 3 and 4 (each within the scatter of the next).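

In this assay, the methyl on the saturated ring carbon, two ring bonds from the ring nitrogen, can now be read on its own, with the chain stereocentre drawn alike in both compounds: no change at the digits printed from compound 3 to compound 4 (within the scatter). With that methyl in place, the chain stereocentre can also be read on its own, and its inversion gives no change at the digits printed from compound 2 to compound 4 (within the scatter), a reading limited by the stereo drawing: the fact that one of compounds 2 and 4 is drawn with a defined configuration and the other without, at the place where they differ. The remaining step, a 2.0-fold higher number from compound 1 to compound 4 (0.30 log units; within the scatter), also stays within the scatter, but it too needs care: the fact that one of compounds 1 and 4 is drawn with a defined configuration and the other without, at the place where they differ.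

Going by these compounds, whether an ethyl or hydroxymethyl group on this ring carbon, or a piperidine in place of the pyrrolidine, would stay level with these compounds remains open. The ring methyl drawn R appears only in compound 1, so its configuration is not separated from the defined stereocentre in the core.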